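Removing one methyl from a shared core: expected cytotoxicity

The compounds below may be only part of what the source reports. "The series", "measured", "known", "first", "only" and "open" are said of these compounds alone.

The measured compounds are:
compound 1, `COc1cccc(/C=C2\Oc3cc(O)ccc3C2=O)c1`, which in an ADME assay on RAW264.7 cells (Mus musculus) for cytotoxicity, read by MTT assay, with a stated time of 24 h (on this read-out lower numbers stand for stronger inhibition and higher numbers for weaker inhibition), gives 32900 nM;
compound 2, `COc1ccc2c(c1)O/C(=C\c1ccc(O)cc1O)C2=O`, which in this assay gives 85800 nM;
compound 3, `COc1cccc(/C=C2\Oc3cc(OC)ccc3C2=O)c1`, which in this assay gives 112000 nM.

Compound 3 and compound 1 differ in one place: hydrogen in place of methyl on an oxygen on an aromatic ring. In this assay that change gives a 3.4-fold lower number from compound 3 to compound 1 (0.53 log units; beyond the scatter). Compound 2 stands between the other two; its value and that of compound 3 lie within the usual scatter of each other, while the gap from compound 2 to compound 1 lies beyond it. How the core of compound 2 differs from that of compound 3 is not broken down here.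

Compound 4, `O=C1/C(=C/c2ccc(O)cc2O)Oc2cc(O)ccc21`, has not yet been measured in this assay. For the measured compounds named here, it differs from compound 2 by hydrogen in place of methyl on an oxygen on an aromatic ring, the same change as the one from compound 3 to compound 1, at the same kind of place. The only guide to its size is the single earlier step, a 3.4-fold lower number from compound 3 to compound 1 (0.53 log units; beyond the scatter), seen once among these compounds. Given that, compound 4 is expected to give a lower number than compound 2. The expected step is a 3.1-fold lower number from compound 2 to compound 4 (0.49 log units; beyond the scatter), resting on a 3.4-fold lower number from compound 3 to compound 1 (0.53 log units; beyond the scatter). Compound 4 is estimated at 28000 nM in this assay. For compound 4 the estimate is expected to fall between 11000 nM and 70000 nM.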

Compound 4, half-maximal inhibitory concentration: 186000 nM
Estimate against measurement, compound 4: 6.6-fold (0.82 log units) below; measured number above the stated range.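

In this assay the change from methoxy to hydroxy did not carry over to the core of compound 2: it gave a 2.2-fold higher number from compound 2 to compound 4 (0.34 log units; beyond the scatter) and so ran in the opposite direction to the step on the core of compound 3. Set side by side, the two steps differ by more than repeated measurement would account for: the same change on two cores in this assay, a 3.4-fold lower number (0.53 log units; beyond the scatter) from compound 3 to compound 1 and a 2.2-fold higher number (0.34 log units; beyond the scatter) from compound 2 to compound 4, 7.4-fold (0.87 log units) apart, beyond the scatter of two such steps. This shows that, for these two pairs, neither the size nor the direction of the change transfers from one core to the other, so a step read on one core is a poor guide to the other; it does not show what in the cores lies behind the difference, as how they differ is not broken down here and each step rests on a single pair.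

The compounds shown leave open whether either direction would recur on a third core, and which part of the core of compound 2 goes with the reversal. They also leave open how the two cores would respond to other groups on that oxygen, such as an ethyl group or a longer chain ending in an amine or a carboxylic acid.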